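This account rests on a few compounds, and the source may have more. Where it says the series, first, only, none or still open, it means among the compounds named here.

Measured so far:
compound 1, `CC(C)=CC[C@@H](OC(=O)CC(C)(O)C(C)C)C1=CC(=O)c2c(O)ccc(O)c2C1=O`: 16900 nM
compound 2, `CCC(O)(CC)CC(=O)O[C@H](CC=C(C)C)C1=CC(=O)c2c(O)ccc(O)c2C1=O`: 67000 nM

Going by the values given here, in a functional assay on DU-145 cells (Homo sapiens) for cytotoxicity, read by MTT assay (a higher number here means a weaker inhibitor, a lower number a stronger inhibitor), compound 2 gives the highest of the two numbers; its only neighbour, compound 1, lies a 4.0-fold higher number from compound 1 to compound 2 (0.60 log units; beyond the scatter) away. Compound 3, `CCCC(CC(=O)O[C@H](CC=C(C)C)C1=CC(=O)c2c(O)ccc(O)c2C1=O)OC(C)=O`, differs from compound 2 by 1-acetoxybutyl in place of 1-ethyl-1-hydroxypropyl on a saturated chain carbon bound to a carbonyl carbon. Among the compounds with values here, the single measured step changed the same position, with a modest outcome, but it swapped one hydroxylated group for another and offers no direct guide for an acetoxy group. The expected move is therefore small and uncertain, a 1.7-fold lower number from compound 2 to compound 3 (0.22 log units; within the scatter). Compound 3 is estimated at 40000 nM, within 10000 nM to 150000 nM.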

Compound 3, half-maximal inhibitory concentration: 55700 nM
The estimate for compound 3 lay 1.4-fold (0.14 log units) below the measured number, and the stated range covers the measured number.
By their numbers in this assay, from the lowest: compound 1; then compounds 3 and 2 (each within the scatter of the next).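

In this assay, 1-acetoxybutyl in place of 1-ethyl-1-hydroxypropyl gives a 1.2-fold lower number from compound 2 to compound 3 (0.08 log units; within the scatter), so at this place a hydroxyl group can give way to an acetoxy group with no change beyond the scatter. Against the 1-hydroxy-1,2-dimethylpropyl group, the same 1-acetoxybutyl group gives a 3.3-fold higher number from compound 1 to compound 3 (0.52 log units; beyond the scatter), which leaves compound 1 with the lowest number of the three. Nothing available explains these numbers. Still open, as far as these compounds go, is how an amine or a carboxylic acid on this chain would read, and whether a ring there would bring the number below that of compound 1.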